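Ester variants on a shared core and a hydrazide

A few compounds are considered here, and "the series" means these few. Any claim that something is new, unique, unknown or untested is made for them only; others in the source may bear on it.

Measured compounds:
compound 1 `CC(C)OC(=O)C(=O)Nc1cccccc1=O`: 76%
compound 2 `CCOC(=O)COC(=O)C(=O)Nc1cccccc1=O`: 69%
compound 3 `O=C(Nc1cccccc1=O)C(=O)Oc1ccccc1`: 68%

In a functional assay on the whole organism (strain Sprague-Dawley CD) for inhibition, with Rattus norvegicus as the target, read by paw edema, at a dose of 10 mg/kg by the intraperitoneal route (a higher number here means a stronger effect of the compound at the dose given, a lower number a weaker effect), compound 1 gives 76%, the highest of the three numbers, though neither other compound is separated from it beyond the scatter: a number 7 percentage points lower from compound 1 to compound 2 (within the scatter) and a number 8 percentage points lower from compound 1 to compound 3 (within the scatter). Between the other two, a number 1 percentage points lower from compound 2 to compound 3 (within the scatter). Compound 4 `NNC(=O)C(=O)Nc1cccccc1=O` differs from compound 1 by aminoamino in place of isopropoxy on a carbonyl carbon. The measured steps only exchange one group for another on an oxygen next to a carbonyl group; none removes that oxygen, so none bears directly on this change. They show only that variation at this carbonyl has moved nothing beyond the scatter. The step expected in this assay is therefore small, a number 11 percentage points lower from compound 1 to compound 4 (beyond the scatter), with wider uncertainty than the measured steps. Compound 4 is estimated at 65%, between 40% and 85%.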

Compound 4, a percentage reported as inhibition, in the whole organism at one dose (the size of the read-out at that dose, not a potency): 64%
Beside the measured number, compound 4's estimate is 1 percentage points above it, within the range that was stated.
By their numbers in this assay, from the lowest: compounds 4, 3, 2 and 1 (each within the scatter of the next, the first and the last beyond it).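

In this assay, within the data shown here, aminoamino in place of isopropoxy on a carbonyl carbon gives a number 12 percentage points lower from compound 1 to compound 4 (beyond the scatter) and is the only step beyond the scatter. Unlike the earlier steps, this change removes the oxygen on that carbonyl carbon, so the read-out does respond to a change at this position, though modestly. No measurement here accounts for the step. Still open, as far as these compounds go, is whether a simple amine or a carboxylic acid on this carbonyl carbon would read like compound 4 or like compound 1.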